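The source may hold more compounds than are shown below. What is called first, only, known or untested is meant among the compounds shown, and "the series" means these compounds.

Measured series, in an assay on isolated protein for inhibition of cathepsin D (Bos taurus); on this read-out lower numbers stand for stronger inhibition and higher numbers for weaker inhibition:
Compound 1 `CC(C)CCNC(=O)[C@H](C)NC(=O)C[C@H](O)[C@H](CC(C)C)NC(=O)[C@@H](NC(=O)OC(C)(C)C)C(C)C` gives 2700 nM.
Compound 2 `CC(C)CCNC(=O)[C@H](C)NC(=O)C[C@H](O)[C@H](CC(C)C)NC(=O)[C@@H](NC(=O)C(C)C)C(C)C` gives 590 nM.
Compound 3 `CCC(C)C(=O)N[C@H](C(=O)N[C@@H](CC(C)C)[C@@H](O)CC(=O)N[C@@H](C)C(=O)NCCC(C)C)C(C)C` gives 230 nM.

Compound 3 holds the lowest number of the three in this assay; its nearest neighbour is compound 2, and compound 1 lies furthest away. The steps that reach it run a 12-fold lower number from compound 1 to compound 3 (1.07 log units; beyond the scatter) and a 2.6-fold lower number from compound 2 to compound 3 (0.41 log units; beyond the scatter), while the move from the carbamate to the simpler amide runs a 4.6-fold lower number from compound 1 to compound 2 (0.66 log units; beyond the scatter).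

Compound 4 `CC(C)CCNC(=O)[C@H](C)NC(=O)C[C@H](O)[C@H](CC(C)C)NC(=O)[C@@H](NC(=O)OC(C)C)C(C)C` differs from compound 3 by isopropoxy in place of sec-butyl on a carbonyl carbon. This returns to a carbamate of the kind seen in compound 1, but with a smaller alkoxy group. The step from compound 1 to compound 2 bears most directly on this change, as it swaps a carbamate for an amide of matching size; the step from compound 1 to compound 3 gives the full span between a carbamate and the best amide. Compound 4 is therefore expected to fall between compound 1 and compound 3, with the number rising from compound 3 by a 5.2-fold higher number from compound 3 to compound 4 (0.72 log units; beyond the scatter).

Compound 4 is estimated at 1200 nM, with a range of 400 nM to 3600 nM in this assay.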

Compound 4, inhibition constant: 620 nM
Beside the measured number, compound 4's estimate is 1.9-fold (0.29 log units) above it; low and high end bracket the measured number.
By their numbers in this assay, from the lowest: compound 3; then compounds 2 and 4 (each within the scatter of the next); then compound 1.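

Isopropoxy in place of sec-butyl on a carbonyl carbon gives a modest loss in this assay (a 2.7-fold higher number from compound 3 to compound 4 (0.43 log units; beyond the scatter)), yet isopropoxy in place of isopropyl leaves compound 2 and compound 4 indistinguishable (a 1.1-fold higher number from compound 2 to compound 4 (0.02 log units; within the scatter)). A carbamate at this place therefore need not read worse than an amide of matching count, and the weak number of compound 1 does not follow from the carbamate alone: removing one methyl from its tert-butoxy group gives (a 4.4-fold lower number from compound 1 to compound 4 (0.64 log units; beyond the scatter)). One added methyl thus lowers the number on the amide and raises it on the carbamate, so its effect depends on the group that carries it: the same change on two cores in this assay, a 2.6-fold lower number (0.41 log units; beyond the scatter) from compound 2 to compound 3 and a 4.4-fold higher number (0.64 log units; beyond the scatter) from compound 4 to compound 1, 11-fold (1.05 log units) apart, beyond the scatter of two such steps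

The compounds shown leave open whether this opposite trend continues with tert-butyl on the same carbonyl carbon or with sec-butoxy, either of which would test it on a further matched pair. From the compounds shown here alone, it also remains open how a longer chain, such as n-pentyl or n-butoxy, would read at this place.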